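A few compounds are considered here, and "the series" means these few. Any claim that something is new, unique, unknown or untested is made for them only; others in the source may bear on it.

Working notes on the series. Compound 1 `O=C(CN(c1nc(Cl)nc2[nH]cnc12)C1CC1)N[C@@H](CC(=O)OCc1ccccc1)C(=O)OCc1ccccc1` stands at the lower of the two values obtained so far; in a functional assay on the whole organism (Tail, strain ICR) with Mus musculus as the target, in the tail flick test, with a stated time of 120 min, at a dose of 25 umol/kg by the oral route (on this read-out lower numbers stand for a weaker effect and higher numbers for a stronger effect at the one dose given), compound 1 gives 12.1%. For the measured compounds named here, the only other measured compound, compound 2 `O=C(O)CNC(=O)CN(c1nc(Cl)nc2[nH]cnc12)C1CC1`, gives 19.8% in this assay, a value that sits within the scatter of compound 1, so the two cannot be ranked. Compound 3 `NC(=O)C[C@H](NC(=O)CN(c1nc(Cl)nc2[nH]cnc12)C1CC1)C(=O)OCc1ccccc1` differs from compound 1 by one change (amino in place of benzyloxy on a carbonyl carbon). Going by the values given here, no measured step covers this change. With compound 1 and compound 2 both weak and indistinguishable, the step of a number 2.9 percentage points higher from compound 1 to compound 3 (within the scatter) is expected to stay within the scatter, in no particular direction. Compound 3 is estimated at 15%, between 4% and 30%.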

Compound 3, a percentage reported as activity, at one dose (the size of the read-out at that dose, not a potency): 15.1%
The estimate for compound 3 lay 0.1 percentage points below the measured number; the range from low to high includes it.
By their numbers in this assay, from the lowest: compounds 1, 3 and 2 (each within the scatter of the next).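

With amino in place of benzyloxy on a carbonyl carbon, the step in this assay is a number 3 percentage points higher from compound 1 to compound 3 (within the scatter). Benzyloxycarbonyl and carbamoyl at this place therefore cannot be told apart on this read-out, even though the change removes a six-membered aromatic ring of carbon only. Nothing available bears on the reason for this result.

Still open, on these data alone, is whether methoxy or dimethylamino on this carbonyl carbon would give a step beyond the scatter. Also open, as far as these compounds go, is how the second benzyloxy group, still present in compound 3, contributes.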